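This account rests on a few compounds, and the source may have more. Where it says the series, first, only, none or still open, it means among the compounds named here.

Series built on the shared core of compound 1 `CN(C)CCCn1cc[n+](C)c1/C=N/O` and compound 2 `CN(CCCn1cc[n+](C)c1/C=N/O)S(=O)(=O)C(F)(F)F`, both characterised in a physicochemical assay for lipophilicity; on this read-out higher numbers stand for higher lipophilicity and lower numbers for lower lipophilicity. In this assay compound 1 gives only a limit, < -3. In this assay compound 2 gives -1.37. The step of a number at least 1.63 log units higher from compound 1 to compound 2 (beyond the scatter) is therefore bounded on one side only, as compound 1 sits at the limit of < -3 in this assay, at which 1 of the 2 values shown sits. Compound 3 `CCS(=O)(=O)CCn1cc[n+](C)c1/C=N/O` carries a different change on the same chain: ethylsulfonyl in place of (dimethylamino)methyl on a saturated chain carbon, two bonds along the chain from an aromatic nitrogen. Going by the values given here, the only measured step, from compound 1 to compound 2, is large, so a rise beyond the scatter is expected as a number at least 0.80 log units higher from compound 1 to compound 3 (beyond the scatter). Compound 3 is estimated at -2.2 in this assay, with a range from -3 to -1.4.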

Compound 3, distribution coefficient: -2.96
The estimate for compound 3 lay 0.76 log units above the measured number; the range from low to high includes it.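

In this assay, ethylsulfonyl in place of (dimethylamino)methyl on a saturated chain carbon, two bonds along the chain from an aromatic nitrogen, gives a number at least 0.04 log units higher from compound 1 to compound 3 (that floor lies within the scatter). The floor set by a number at least 1.63 log units higher from compound 1 to compound 2 (beyond the scatter) therefore does not carry over to this change at this position. The full size of the step to compound 3 stays unread because compound 1 gives only a limit: the limit of < -3 in this assay, at which 1 of the 3 values shown sits.

The compounds shown leave open how an amide at this position would read in this assay. They also leave open whether a longer chain carrying ethylsulfonyl would read differently.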